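This account rests on a few compounds, and the source may have more. Where it says the series, first, only, none or still open, it means among the compounds named here.

Compound 1 `Cc1cccc(N2C(=O)CSC2c2cccc(C(=O)NCCCCc3ccccc3)c2)c1`: 749 mL.min-1.g-1
Compound 2 `CC(F)(F)c1cccc(N2C(=O)CSC2c2cccc(C(=O)NCCCCc3ccccc3)c2)c1`: 912 mL.min-1.g-1

In an ADME assay on microsomes from liver (Canis lupus familiaris) for metabolic stability, read by LC-MS, using NADPH, with a stated time of 10 min, tested at 0.1 uM (a higher number here means faster removal of the compound, a lower number slower removal), compound 2 gives 912 mL.min-1.g-1, and compound 1 lies within the usual scatter of that number. The next compound to be measured is compound 3 `O=C(NCCCCc1ccccc1)c1cccc(C2SCC(=O)N2c2ccc(C3CC3)cc2)c1`. The change from compound 2 is a group of 9 heavy atoms (9 carbon; one three-membered non-aromatic ring of carbon only, one six-membered aromatic ring of carbon only) in place of a group of 10 heavy atoms (8 carbon, 2 fluorine; one six-membered aromatic ring of carbon only), on an amide-type nitrogen in a ring.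

Going by the values given here, only one measured step bears on this change: a 1.2-fold higher number from compound 1 to compound 2 (0.09 log units; within the scatter). It puts 1,1-difluoroethyl in place of methyl on an aromatic carbon. Among the compounds with values here, this is a weak guide, as no measured compound carries 4-cyclopropylphenyl. Within the data shown here, with only this small step to go on, no change beyond the scatter is expected, and no direction can be called. The expected step is a 1.1-fold lower number from compound 2 to compound 3 (0.06 log units; within the scatter). For compound 3, the estimated value is 800 mL.min-1.g-1, with an expected range of 420 mL.min-1.g-1 to 1400 mL.min-1.g-1.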

Compound 3, intrinsic clearance in microsomes: 1080 mL.min-1.g-1
Beside the measured number, compound 3's estimate is 1.4-fold (0.13 log units) below it, and the stated range covers the measured number.
By their numbers in this assay, from the lowest: compounds 1, 2 and 3 (each within the scatter of the next).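

On the amide-type nitrogen in a ring, 4-cyclopropylphenyl can be compared with two other groups: the group of compound 2 (a 1.2-fold higher number from compound 2 to compound 3 (0.07 log units; within the scatter)) and 3-methylphenyl (a 1.4-fold higher number from compound 1 to compound 3 (0.16 log units; within the scatter)). In this assay, this position now carries three different groups, one of them with a three-membered carbon ring and no fluorine, and neither new step leaves the usual scatter of repeated measurements. No measurement at hand offers an explanation for this result.

All three groups on this nitrogen are phenyl rings bearing a carbon-based substituent, so the compounds shown leave open what a substituent of another kind, such as an amine or a carboxylic acid, would do here. They also leave open whether a change elsewhere on the shared core, such as a longer chain on the amide, would move the number beyond the scatter.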